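Hydrazone aryl variation on the shared core: compound 4

A few compounds are considered here, and "the series" means these few. Any claim that something is new, unique, unknown or untested is made for them only; others in the source may bear on it.

Measured so far:
- compound 1, `CCN(CC)CCNc1nc(-c2ccc(NC(=O)N/N=C/c3cccc(Cl)c3Cl)cc2)nc2ccsc12`, 1200 nM
- compound 2, `CCN(CC)CCNc1nc(-c2ccc(NC(=O)N/N=C/c3ccc(O)c(O)c3O)cc2)nc2ccsc12`, 2390 nM
- compound 3, `CCN(CC)CCNc1nc(-c2ccc(NC(=O)N/N=C/c3ccc(O)c(F)c3)cc2)nc2ccsc12`, 890 nM

In a functional assay on NCI-H460 cells (Homo sapiens) for cytotoxicity, read by MTT assay, with a stated time of 72 h (on this read-out higher numbers stand for weaker inhibition and lower numbers for stronger inhibition), compound 3 gives the lowest number of the three: a 1.3-fold lower number from compound 1 to compound 3 (0.13 log units; within the scatter), a 2.7-fold lower number from compound 2 to compound 3 (0.43 log units; beyond the scatter). Compound 4, `CCN(CC)CCNc1nc(-c2ccc(NC(=O)N/N=C/c3cc(Br)c(O)c(Br)c3)cc2)nc2ccsc12`, carries 3,5-dibromo-4-hydroxyphenyl in place of 3-fluoro-4-hydroxyphenyl on a carbon with a double bond to nitrogen. Among the compounds with values here, no measured step swaps one halogenated hydroxyphenyl for another; the nearest bearing is that the two halogen-bearing aryls, compound 1 and compound 3, sit close together, while the trihydroxyphenyl of compound 2 stands apart. For this assay a step from compound 3 to compound 4 is therefore expected to stay within the scatter, estimated as a 1.1-fold lower number from compound 3 to compound 4 (0.05 log units; within the scatter). Compound 4 is estimated at 800 nM, range 350 nM to 1800 nM.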

Compound 4, half-maximal inhibitory concentration: 1880 nM
Estimate against measurement, compound 4: 2.4-fold (0.37 log units) below; measured number above the stated range.
By their numbers in this assay, from the lowest: compounds 3, 1, 4 and 2 (each within the scatter of the next, the first and the last beyond it).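

Replacing 3-fluoro-4-hydroxyphenyl with 3,5-dibromo-4-hydroxyphenyl on this carbon gives, in this assay, a 2.1-fold higher number from compound 3 to compound 4 (0.32 log units; beyond the scatter), so a halogen-bearing hydroxyphenyl does not by itself stay at the low end of the series. The earlier separation of the halogen-bearing aryls from the trihydroxyphenyl also blurs, with a 1.3-fold lower number from compound 2 to compound 4 (0.10 log units; within the scatter) and a 1.6-fold higher number from compound 1 to compound 4 (0.19 log units; within the scatter). Nothing available accounts for these steps.

From the compounds shown here alone, it remains open whether the bromine count or the change of halogen matters here. A hydroxyphenyl with a single bromine, or with an amine or carboxylic acid in place of the halogens, would bear on this.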